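The compounds below may be only part of what the source reports. "The series", "measured", "known", "first", "only" and "open" are said of these compounds alone.

Measured compounds:
compound 1, `O=[N+]([O-])C1=NNc2nc(C(F)(F)F)nn2C1c1c(O)cc(O)cc1O`, 252000 nM
compound 2, `O=[N+]([O-])C1=NNc2nc(C(F)(F)F)nn2C1c1ccc(O)cc1O`, 108000 nM
compound 3, `O=[N+]([O-])C1=CNc2nc(-c3ccco3)nn2C1c1ccc(O)cc1O`, 119000 nM

All three were run in an ADME assay on MDCK cells (Canis lupus familiaris) for cytotoxicity; a lower number here means that less compound is tolerated, a higher number that more compound is tolerated. In this assay compound 2 gives 108000 nM and compound 1 gives 252000 nM; the change between them is hydroxy in place of hydrogen on an aromatic carbon, and it made a 2.3-fold higher number from compound 2 to compound 1 (0.37 log units; beyond the scatter). Compound 3 gives 119000 nM; the difference between the cores of compound 2 and compound 3 is not broken down here.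

Compound 4, `O=[N+]([O-])C1=CNc2nc(-c3ccco3)nn2C1c1ccc(O)c(O)c1O`, is not yet measured. It arises from compound 3 by hydroxy in place of hydrogen on an aromatic carbon. This is the same kind of change as that from compound 2 to compound 1, though the surroundings differ: there the new group sat ortho to a large group and meta to two hydroxy groups, here it sits ortho to two hydroxy groups and meta to a large group. On the strength of compound 2 to compound 1, compound 4 is expected to show a 1.7-fold higher number from compound 3 to compound 4 (0.23 log units; within the scatter) in this assay. Compound 4 is therefore estimated at 200000 nM, between 100000 nM and 400000 nM.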

Compound 4, half-maximal cytotoxic concentration: 317000 nM
Compound 4: middle estimate off by 1.6-fold (0.20 log units), on the low side; the measured number falls inside the stated range.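

In this assay, hydroxy in place of hydrogen on an aromatic carbon gave a 2.7-fold higher number from compound 3 to compound 4 (0.43 log units; beyond the scatter). Set beside the earlier case, the step carried from one core to the other at much the same size: the same change on two cores in this assay, a 2.3-fold higher number (0.37 log units; beyond the scatter) from compound 2 to compound 1 and a 2.7-fold higher number (0.43 log units; beyond the scatter) from compound 3 to compound 4, 1.1-fold (0.06 log units) apart, within the scatter of two such steps. Among these compounds, this rests on only two pairs, with the new hydroxy in different surroundings in each, so it shows that the step held on these two cores but not that it would hold on any other core.

The compounds shown leave open whether another group in that place, such as a methoxy or an amine, would move the number the same way. Also open, going by these compounds, is whether the step would persist on a ring carrying no other hydroxy groups.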